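Trifluoromethyl to methyl on a carbonyl carbon

The compounds below may be only part of what the source reports. "The series", "measured", "known", "first", "only" and "open" are said of these compounds alone.

For compound 1 (`Cc1ccc(N)cc1S(=O)(=O)N(C)/N=C/c1cnn2ccc(C#N)cc12`) the entry in a functional assay on NZB5 cells (Homo sapiens) for inhibition, read by thymidine incorporation, with a stated time of 5 days (a lower number here means a stronger inhibitor, a higher number a weaker inhibitor), reads "not determined" (no result reported) and so offers no number to compare. In this assay, going by the values given here, compound 2 (`Cc1ccc(NC(=O)C(F)(F)F)cc1S(=O)(=O)N(C)/N=C/c1cnn2ccc(C#N)cc12`) gives 2300 nM as the only number so far, which means it cannot yet be ranked against anything. Compound 3 (`CC(=O)Nc1ccc(C)c(S(=O)(=O)N(C)/N=C/c2cnn3ccc(C#N)cc23)c1`) still awaits measurement. It carries methyl in place of trifluoromethyl on a carbonyl carbon, so the ((trifluoromethyl)carbonyl)amino group becomes acetamido while the shared core stays the same. Among the compounds with values here, no measured step exists to guide the expectation, so no change beyond the usual scatter is expected in this assay, and no direction can be called firm. The estimated move, a 1.3-fold lower number from compound 2 to compound 3 (0.11 log units; within the scatter) in size, is therefore a small one. Compound 3 is expected at 1800 nM with an estimated range from 500 nM to 6000 nM in this measurement.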

Compound 3, half-maximal inhibitory concentration: > 20000 nM
Compound 3 was reported as a limit (the forecaster's own chance of this, stated with the estimate: 10%); middle value at least 11-fold (1.04 log units) away from the limit.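

In this assay, the group on the carbonyl carbon clearly matters: replacing trifluoromethyl with methyl, with the shared core unchanged, gives an at least 8.6-fold higher number from compound 2 to compound 3 (0.93 log units; beyond the scatter). Going by these compounds alone, this is the first measured step at this position, and it shows that compound 2 is the stronger inhibitor of the pair. Compound 3 gives > 20000 nM, which is a limit and not a number, so the step shows only a minimum size and its full size stays unknown: the limit of > 20000 nM in this assay, at which 1 of the 3 values shown sits.

As far as these compounds go, the two ends of this single swap say nothing about groups in between or beyond them, so it remains open how difluoromethyl or a longer chain such as ethyl would behave on the same carbonyl carbon. From the compounds shown here alone, whether any such group would give a stronger inhibitor than compound 2 also remains open.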